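The source may report more compounds than this note shows. Statements on the series, on what has been measured and on what is new or still open speak of the compounds shown alone.

Measured in an ADME assay on CCRF-CEM cells (Homo sapiens) for cytotoxicity, with a stated time of 5 days; a lower number here means a stronger inhibitor, a higher number a weaker inhibitor:

- Compound 1 `[N-]=[N+]=N[C@H]1C[C@H](n2cnc3c(NC4CC4)nc(Cl)nc32)O[C@@H]1CO` gives > 100000 nM
- Compound 2 `COc1nc(F)nc2c1ncn2[C@H]1C[C@H](N=[N+]=[N-])[C@@H](CO)O1` gives > 100000 nM
- Compound 3 `[N-]=[N+]=N[C@H]1C[C@H](n2cnc3c(Cl)nc(F)nc32)O[C@@H]1CO` gives 13300 nM

Compound 3 is the only one of the three with an actual number, so nothing measured can be ranked against it exactly. Compound 1 gives > 100000 nM, which is a limit of the assay and not a number. Compound 2 gives > 100000 nM, which is also a limit.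

Compound 4 `[N-]=[N+]=N[C@H]1C[C@H](n2cnc3c(N)nc(F)nc32)O[C@@H]1CO` has not yet been measured. It differs from compound 3 in one place, with amino in place of chloro on an aromatic carbon. Within the data shown here, one measured step bears on this change, since it also involves chloro on an aromatic carbon. That step is an at least 7.5-fold lower number from compound 2 to compound 3 (0.87 log units; beyond the scatter), with chloro in place of methoxy, and it is beyond the scatter. Here, chloro came with the lower number. This is a single example with a different incoming group, so it gives only a rough guide. A modest move towards a higher number, meaning a weaker inhibitor, is therefore expected in this assay. The expected step is a 2.6-fold higher number from compound 3 to compound 4 (0.42 log units; beyond the scatter). For compound 4 the estimated value is 35000 nM, with an expected range from 6000 nM to 100000 nM. A result at the ceiling is also possible, given (the limit of > 100000 nM in this assay, at which 2 of the 3 values shown sit).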

Compound 4, half-maximal inhibitory concentration: 30100 nM
Beside the measured number, compound 4's estimate is 1.2-fold (0.07 log units) above it; low and high end bracket the measured number.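

In this assay, the aromatic carbon next to the ring nitrogen can now be compared across three groups on an otherwise shared core, and amino falls between chloro and methoxy: a 2.3-fold higher number from compound 3 to compound 4 (0.35 log units; beyond the scatter), while an at least 3.3-fold lower number from compound 2 to compound 4 (0.52 log units; beyond the scatter). Compound 2 gives > 100000 nM, which is a limit of the assay and not a number. The earlier compounds showed only that chloro gave a lower number than methoxy, whereas the order at this position now runs from chloro through amino to methoxy, with the distance from amino to methoxy known only as a minimum: the limit of > 100000 nM in this assay, at which 2 of the 4 values shown sit.

The compounds shown leave open whether a methylamino group, a hydroxyl group or a bromo group at this position would give a number closer to that of chloro or closer to that of amino. Also open, on these data alone, is whether the same order would hold with a group other than fluoro on the ring, since compound 1 differs from compound 3 in more than one place and cannot settle that.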